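From (3-phenylprop-2-en-1-yl)oxy to butoxy

This account rests on a few compounds, and the source may have more. Where it says the series, first, only, none or still open, it means among the compounds named here.

In a functional assay on aorta (Rattus norvegicus, strain Sprague-Dawley) for inhibition (a higher number here means that more compound is needed for the effect, a lower number that less compound is needed), compound 1 `Cc1cc2c(c3c1C[C@@H]1[C@@H](C)CO[C@]1(C)O3)C[C@@H]1[C@@H](C)CO[C@]1(C)O2` gives 40000 nM, compound 2 `C=C=CCOc1cc2c(c3c1C[C@@H]1[C@@H](C)CO[C@]1(C)O3)C[C@@H]1[C@@H](C)CO[C@]1(C)O2` gives 12000 nM and compound 3 `C[C@H]1CO[C@]2(C)Oc3cc(OC/C=C/c4ccccc4)c4c(c3C[C@H]12)O[C@@]1(C)OC[C@H](C)[C@H]1C4` gives 64000 nM. That leaves compound 3 level with compound 1 and with a higher number than compound 2. Compound 4 `CCCCOc1cc2c(c3c1C[C@@H]1[C@@H](C)CO[C@]1(C)O3)C[C@@H]1[C@@H](C)CO[C@]1(C)O2` carries propyl in place of 2-phenylethenyl on a saturated chain carbon bound to an oxygen on an aromatic ring. Among the measured compounds shown here, the closest precedent is a 5.3-fold higher number from compound 2 to compound 3 (0.73 log units; beyond the scatter), which brought in that same 2-phenylethenyl, while a 3.3-fold lower number from compound 1 to compound 2 (0.52 log units; beyond the scatter) and a 1.6-fold higher number from compound 1 to compound 3 (0.20 log units; within the scatter) frame the range. A modest step toward a lower number is therefore expected in this assay, a 2.6-fold lower number from compound 3 to compound 4 (0.41 log units; beyond the scatter). Compound 4 is estimated at 25000 nM, with an expected range of 9000 nM to 70000 nM.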

Compound 4, half-maximal effective concentration: 111000 nM
Beside the measured number, compound 4's estimate is 4.4-fold (0.65 log units) below it; the measured number lies above the stated range.
By their numbers in this assay, from the lowest: compound 2; then compounds 1, 3 and 4 (each within the scatter of the next, the first and the last beyond it).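

In this assay, butoxy and (3-phenylprop-2-en-1-yl)oxy cannot be told apart at this position, a 1.7-fold higher number from compound 3 to compound 4 (0.24 log units; within the scatter), so the phenyl ring and double bond can go without a change beyond the scatter. Against the propa-1,2-dien-1-yl chain the picture differs, a 9.3-fold higher number from compound 2 to compound 4 (0.97 log units; beyond the scatter), and against methyl there is a 2.8-fold higher number from compound 1 to compound 4 (0.44 log units; beyond the scatter), so an ether chain here does not by itself bring a lower number. Nothing available explains the difference between these chains. Open, on these data alone, is what a carboxylic acid or an amine at the end of the chain would do in this assay.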